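Pyridinyl attachment change, compound 3 to compound 4

This account rests on a few compounds, and the source may have more. Where it says the series, first, only, none or still open, it means among the compounds named here.

Three compounds of the series have a number in a functional assay for inhibition, with Homo sapiens as the target; on this read-out higher numbers stand for weaker inhibition and lower numbers for stronger inhibition. Among the compounds with values here, compound 1 `CC1CCN(c2ccc(Nc3nccc(-c4cccnc4)n3)cc2)CC1` gives 500 nM and compound 2 `CN(C)CCCOc1ccc(Nc2nccc(-c3cccnc3)n2)cc1` gives 600 nM; the one single-point step, a 1.2-fold higher number from compound 1 to compound 2 (0.08 log units; within the scatter), lies within the scatter. Compound 3 `c1ccc(-c2ccnc(Nc3ccc(-n4ccnc4)cc3)n2)nc1` gives 1400 nM, the highest of the three, beyond the scatter from both others. The next compound is compound 4 `c1cncc(-c2ccnc(Nc3ccc(-n4ccnc4)cc3)n2)c1`, and the change is pyridin-3-yl in place of pyridin-2-yl on an aromatic carbon. Within the data shown here, no measured step covers this change: compounds 1 and 2 carry the entering group but differ from compound 3 elsewhere too, so their values show only that the entering group appears among the lower numbers. The expected step of a 1.6-fold lower number from compound 3 to compound 4 (0.19 log units; within the scatter) is therefore a modest, uncertain move toward lower numbers. Compound 4 is estimated at 900 nM, range 350 nM to 2300 nM.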

Compound 4, half-maximal inhibitory concentration: 1300 nM
The estimate for compound 4 lay 1.4-fold (0.16 log units) below the measured number; the measured number falls inside the stated range.
By their numbers in this assay, from the lowest: compounds 1 and 2 (each within the scatter of the next); then compounds 4 and 3 (each within the scatter of the next).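

Pyridin-3-yl in place of pyridin-2-yl leaves the number in this assay within the scatter (a 1.1-fold lower number from compound 3 to compound 4 (0.03 log units; within the scatter)), so this attachment change does not separate the pair. With pyridin-3-yl held fixed, 1H-imidazol-1-yl gives a higher number than 3-(dimethylamino)propoxy (a 2.2-fold higher number from compound 2 to compound 4 (0.34 log units; beyond the scatter)) and 4-methylpiperidin-1-yl (a 2.6-fold higher number from compound 1 to compound 4 (0.41 log units; beyond the scatter)), so the steps beyond the scatter lie at that group and not at the pyridine attachment. No evidence on hand explains these results. Open: how pyridin-4-yl compares at this position, and whether morpholin-4-yl or a carboxylic acid in place of 1H-imidazol-1-yl shifts the number.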